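The source may report more compounds than this note shows. Statements on the series, on what has been measured and on what is new or still open speak of the compounds shown alone.

In a functional assay on G-361 cells (Homo sapiens) for antiproliferative activity, with a stated time of 72 h (on this read-out lower numbers stand for stronger inhibition and higher numbers for weaker inhibition), compound 3 (`COc1ccccc1CNc1ncnc2c1ncn2[C@@H]1O[C@H](CO)[C@@H](O)[C@H]1O`) gives > 166000 nM as a limit and not a number, so its standing is known only as a limit. Compound 2 (`OC[C@H]1O[C@@H](n2cnc3c(NCc4ccc(Cl)cc4)ncnc32)[C@H](O)[C@@H]1O`) gives > 166000 nM and this too is a limit. For compound 1 (`OC[C@H]1O[C@@H](n2cnc3c(NCc4ccccc4F)ncnc32)[C@H](O)[C@@H]1O`) the entry reads "not determined" (no result reported) and supplies no number. That leaves the limit of > 166000 nM in this assay, at which 2 of the 3 values shown sit, as the whole of the quantitative picture.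

The change to compound 4 (`OC[C@H]1O[C@@H](n2cnc3c(NCc4ccc(F)cc4F)ncnc32)[C@H](O)[C@@H]1O`) is 2,4-difluorophenyl in place of 2-methoxyphenyl on a saturated chain carbon bound to a nitrogen on an aromatic ring and puts 2,4-difluorophenyl in place of 2-methoxyphenyl on a saturated chain carbon bound to a nitrogen on an aromatic ring. Within the data shown here, the one measured step that bears on it, a step that the two limits leave unreadable from compound 2 to compound 3 with 2-methoxyphenyl in place of 4-chlorophenyl at the same place, gives no size to carry over. No readable step in either direction is therefore expected in this assay and a further report as a limit is the likeliest outcome. The expected a number no higher from compound 3 to compound 4 (the limit leaves the size open) is nominal only, as it starts from a limit. The estimate for compound 4 is 166000 nM with an expected range from 50000 nM to 300000 nM for any number that is reported.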

Compound 4, half-maximal inhibitory concentration: > 166000 nM
Compound 4 was reported as a limit; the forecaster's own chance of this, stated with the estimate: 75%; the middle value lies on the limit itself.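

In this assay compound 4 gives > 166000 nM, a limit and not a number. Compound 2 and compound 3 are also reported as limits, so neither step to compound 4 can be read. The compounds shown leave open whether any of these groups on the shared core would give a number in this assay, and how far they would differ: the limit of > 166000 nM in this assay, at which 3 of the 4 values shown sit.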